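Stereo-undefined analogue of a tetrabrominated benzotriazole alkanol

This account rests on a few compounds, and the source may have more. Where it says the series, first, only, none or still open, it means among the compounds named here.

Measured so far in a functional assay on MCF7 cells (Homo sapiens) for antiproliferative activity, read by MTT assay, with a stated time of 48 h, tested at 50 uM; on this read-out higher numbers stand for a weaker effect at the one concentration tested and lower numbers for a stronger effect:
compound 1, `OC(CCn1nc2c(Br)c(Br)c(Br)c(Br)c2n1)c1ccc(F)cc1`, 7%
compound 2, `C[C@H](O)CCn1nc2c(Br)c(Br)c(Br)c(Br)c2n1`, 87%

Compound 2 stands highest of the two numbers on this read-out; its nearest neighbour is compound 1, which lies lower by a gap beyond the scatter. Within the data shown here, compound 1 carries an aryl group on the hydroxyl-bearing carbon where compound 2 carries a methyl, but no step between the two is drawn, so the pair only shows that compound 1 reads low and compound 2 reads high.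

Compound 3, `CC(O)CCn1nc2c(Br)c(Br)c(Br)c(Br)c2n1`, is the next compound for this assay. It differs from compound 2 as follows: the two compounds have the same atoms and bonds; at least one stereo element is drawn with a configuration in one of them and without one in the other: 1 of 1 stereo elements differ; a stereocentre at a saturated chain carbon is drawn S in compound 2 and without a configuration in compound 3. The same atoms and bonds are present; only the drawn configuration at the chain stereocentre is absent in compound 3.

Among the measured compounds shown here, nothing among the measured compounds shows how the drawn configuration bears on this read-out. With identical atoms and bonds, the step from compound 2 to compound 3 is expected to be small, most likely none beyond the scatter, with some allowance for a lower number: a number 7 percentage points lower from compound 2 to compound 3 (within the scatter). Compound 3 is therefore estimated at 80%, within 55% to 100%.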

Compound 3, a percentage reported as activity, at one concentration (the size of the read-out at that concentration, not a potency): 76%
The estimate for compound 3 lay 4 percentage points above the measured number; measured number inside the range.
By their numbers in this assay, from the lowest: compound 1; then compound 3; then compound 2.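

In this assay, the drawn configuration at the chain stereocentre now has a step of its own, modest in size, a number 11 percentage points lower from compound 2 to compound 3 (beyond the scatter), and with the same atoms and bonds on both sides, the only difference to which it can be tied is this: the fact that one of compounds 2 and 3 is drawn with a defined configuration and the other without, at the place where they differ. The saturated chain carbon bound to the oxygen also gains a readable step for methyl in place of 4-fluorophenyl, a number 69 percentage points higher from compound 1 to compound 3 (beyond the scatter), which the earlier pair could not give. At this carbon, the exchange of 4-fluorophenyl for methyl therefore weighs far more on this read-out than the loss of the drawn configuration, so the low number of compound 1 goes with the aryl group rather than with stereo drawing.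

Open, as far as these compounds go, is how the opposite drawn configuration at this stereocentre would read, and whether the 4-fluorophenyl step depends on the configuration at this carbon. Also open, from the compounds shown here alone, is whether the fluorine matters at all, which a plain phenyl would test, and how an ethyl group or a longer chain in place of methyl would fall between these numbers.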